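Removing the Fluoro of Compound 3: Compound 4

The compounds below may be only part of what the source reports. "The series", "measured", "known", "first", "only" and "open" are said of these compounds alone.

Compound 1 `COC(=O)c1ccc(C2SCC(=O)N2c2ccc(N3CCN(Cc4cc(OC)c(OC)c(OC)c4)CC3)cn2)c(OC)c1`: in a functional assay on NALM-6 cells (Homo sapiens) for antiproliferative activity, read by MTT assay and trypan blue exclusion, with a stated time of 72 h (on this read-out lower numbers stand for stronger inhibition and higher numbers for weaker inhibition), compound 1 gives > 100000 nM, a limit of the assay and not a number.
Compound 2 `COC(=O)c1ccc(C2SCC(=O)N2c2ccc(N3CCN(Cc4cccc(C)c4)CC3)cn2)c(OC)c1`: in this assay compound 2 gives 27300 nM.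
Compound 3 `COC(=O)c1ccc(C2SCC(=O)N2c2ccc(N3CCN(S(=O)(=O)c4ccc(F)cc4)CC3)cn2)c(OC)c1`: in this assay compound 3 gives > 100000 nM, again a limit and not a number.

For the measured compounds named here, compound 3 therefore stands at the limit of > 100000 nM in this assay, at which 2 of the 3 values shown sit, and compound 1 sits at the same limit, so compound 2 is the only member of the set with a measured number. The two measured steps frame that number: an at least 3.6-fold lower number from compound 1 to compound 2 (0.56 log units; beyond the scatter), and then an at least 3.6-fold higher number from compound 2 to compound 3 (0.56 log units; beyond the scatter).

Compound 4 `COC(=O)c1ccc(C2SCC(=O)N2c2ccc(N3CCN(S(=O)(=O)c4ccccc4)CC3)cn2)c(OC)c1` differs from compound 3 by hydrogen in place of fluoro on an aromatic carbon. Neither measured step bears directly on a change of this kind: an at least 3.6-fold lower number from compound 1 to compound 2 (0.56 log units; beyond the scatter) exchanged one aromatic arm for another, and an at least 3.6-fold higher number from compound 2 to compound 3 (0.56 log units; beyond the scatter) replaced the 3-methylbenzyl with a (4-fluorophenyl)sulfonyl. Because compound 3 already sits at the limit of > 100000 nM in this assay, at which 2 of the 3 values shown sit, a change as small as a single fluoro is expected to leave the read-out where it is, so the expected step is a number no higher from compound 3 to compound 4 (the limit leaves the size open), none beyond the scatter. Compound 4 is therefore expected to give about 100000 nM in this assay, between 30000 nM and 400000 nM, most likely reported as a limit once more.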

Compound 4, half-maximal inhibitory concentration: 48400 nM
Compound 4: the middle estimate sits 2.1-fold (0.32 log units) above what was measured; low and high end bracket the measured number.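

In this assay this place on the aromatic ring proves sensitive to a single atom, since hydrogen in place of fluoro gives an at least 2.0-fold lower number from compound 3 to compound 4 (0.31 log units; beyond the scatter). The value of compound 3 is a limit of the assay and not a number, so the full size of this step stays open: the limit of > 100000 nM in this assay, at which 2 of the 4 values shown sit.

With a 1.8-fold higher number from compound 2 to compound 4 (0.25 log units; within the scatter), the phenylsulfonyl and 3-methylbenzyl groups on the ring amine nitrogen cannot be told apart, so the earlier at least 3.6-fold higher number from compound 2 to compound 3 (0.56 log units; beyond the scatter) now applies to the (4-fluorophenyl)sulfonyl group and cannot be read as a penalty for the sulfonyl link as such.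

The compounds shown leave open how a chloro, a methyl, a methoxy or an amine at this same place on the phenylsulfonyl ring would read, and so whether the fluoro stands alone in this behaviour or belongs to a wider trend. They also leave open whether a fluoro at the matching place on the benzyl ring of compound 2 would give a similar step, or whether this sensitivity belongs to the sulfonyl series only.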